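A few compounds are considered here, and "the series" means these few. Any claim that something is new, unique, unknown or untested is made for them only; others in the source may bear on it.

Compound 1, `S=C=Nc1ccc(OCC2=NCCN2)cc1`, gives 108% in an ADME assay on the whole organism (thoracic aorta) with Rattus norvegicus as the target; a lower number here means a smaller maximal response, a higher number a larger maximal response.
Compound 2, `Cc1ccc(CC2=NCCN2)cc1`, gives 14% in this assay.

Of the two measured compounds, compound 2 has the lower maximal response; its nearest neighbour is compound 1, whose value lies higher by a margin beyond the usual scatter. Among the measured compounds shown here, the two compounds differ in more than one place, so no single step connects them; their values show only that compound 1 reaches a far larger response than compound 2.

Compound 3, `S=C=Nc1ccc(CC2=NCCN2)cc1`, is not yet measured. From compound 2 it differs by a group of 3 heavy atoms (1 carbon, 1 nitrogen, 1 sulfur; no ring) in place of one carbon atom, on an aromatic carbon. Compound 3 thus carries the same group of 3 heavy atoms that compound 1 bears, while keeping the rest of compound 2.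

Compound 1 reaches 108% with that group present. A large upward step in this assay is therefore expected, a number 61 percentage points higher from compound 2 to compound 3 (beyond the scatter). Compound 3 is estimated to give about 75%, within 35% to 110%.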

Compound 3, largest response reached (Emax), in percent of the reference or control that the assay uses: 118%
For compound 3 the middle estimate is 43 percentage points below the measured one; measured number outside the range, above it.
By their numbers in this assay, from the lowest: compound 2; then compounds 1 and 3 (each within the scatter of the next).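

In this assay, among the compounds shown here, putting the group of 3 heavy atoms (1 carbon, 1 nitrogen, 1 sulfur) in place of the methyl on this aromatic carbon gives a number 104 percentage points higher from compound 2 to compound 3 (beyond the scatter) and is the first single-place step available, so the large rise in maximal response can now be tied to this one change on the core of compound 2. Compound 3 at 118% and compound 1 at 108% lie within the usual scatter of each other, so both compounds bearing this group stand at a similar level. Nothing measured here accounts for the size of the step.

From the compounds shown here alone, whether another group on this carbon, such as an amine or a longer alkyl chain, would also give a large response remains open. So does the effect of placing the same group elsewhere on the ring.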